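Methoxy Exchanged for 4-Fluorophenyl on the Shared Core

A few compounds are considered here, and "the series" means these few. Any claim that something is new, unique, unknown or untested is made for them only; others in the source may bear on it.

Compound 1, `C=C[C@@](C)(/C=C/c1ccc(OC)cc1)CCC=C(C)C`: in a functional assay on Raji cells (Homo sapiens) for cytotoxicity, with a stated time of 72 h (on this read-out lower numbers stand for an effect already at smaller amounts and higher numbers for an effect only at larger amounts of compound), compound 1 gives > 26000 nM, which is a limit of the assay.
Compound 2, `C=C[C@@](C)(/C=C/c1ccc(O)cc1)CCCO`: in this assay compound 2 gives > 26000 nM, again a limit.
Compound 3, `CC(C)=CCC[C@@](C)(/C=C/c1ccc(C)cc1)/C=C/c1ccc(O)cc1`: in this assay compound 3 gives > 26000 nM, also a limit.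

Compound 1 therefore stands at the same place as every other measured compound: the limit of > 26000 nM in this assay, at which 3 of the 3 values shown sit. No pair of these compounds differs in one place only, so no measured step is available to guide expectations.

Compound 4, `C=C[C@@](C)(/C=C/c1ccc(-c2ccc(F)cc2)cc1)CCC=C(C)C`, differs from compound 1 in one place: 4-fluorophenyl in place of methoxy on an aromatic carbon. With all three values sitting at the limit, no direction is indicated, and the step from compound 1 to compound 4 is expected to be a number no higher from compound 1 to compound 4 (the limit leaves the size open), that is, none beyond the usual scatter. Compound 4 is accordingly estimated at 26000 nM, within 8000 nM to 80000 nM, most likely reported again as a limit.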

Compound 4, half-maximal effective concentration: > 26000 nM
Compound 4 was reported as a limit; the forecaster's own chance of this, stated with the estimate: 70%; the middle value sits exactly at the limit.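

Compound 1 and compound 4 both stand at a limit in this assay, so the step between them cannot be read. The compounds shown leave open what value any of them would actually take: the limit of > 26000 nM in this assay, at which 4 of the 4 values shown sit.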